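The compounds below may be only part of what the source reports. "The series", "measured", "known", "first", "only" and "open" are said of these compounds alone.

Measured so far in a functional assay, read by spectrophotometry, with a stated time of 30 min; on this read-out higher numbers stand for an effect only at larger amounts of compound and lower numbers for an effect already at smaller amounts:
Compound 1 `COc1cc(C2Oc3cc([C@H]4Oc5cc(O)cc(O)c5C(=O)[C@@H]4O)ccc3OC2COC(=O)c2ccc([N+](=O)[O-])cc2)ccc1O` gives only a limit, > 300000 nM.
Compound 2 `COc1cc(C2Oc3cc([C@H]4Oc5cc(O)cc(O)c5C(=O)[C@@H]4O)ccc3OC2COC(=O)c2cccc(Cl)c2)ccc1O` gives 106000 nM.
Compound 3 `CCOC(=O)CC(=O)OCC1Oc2ccc([C@H]3Oc4cc(O)cc(O)c4C(=O)[C@@H]3O)cc2OC1c1ccc(O)c(OC)c1` gives 101000 nM.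

Compound 2 and compound 3 lie within the scatter of each other, a 1.0-fold lower number from compound 2 to compound 3 (0.02 log units; within the scatter). Compound 1 gives only a limit. Compound 4 `COc1cc(C2Oc3cc([C@H]4Oc5cc(O)cc(O)c5C(=O)[C@@H]4O)ccc3OC2COC(=O)/C=C/c2ccc(C)cc2)ccc1O` differs from compound 2 at the ester group: 2-(4-methylphenyl)ethenyl in place of 3-chlorophenyl on a carbonyl carbon. Two steps at this same position bear on the change: an at least 2.8-fold lower number from compound 1 to compound 2 (0.45 log units; beyond the scatter) and a 1.0-fold lower number from compound 2 to compound 3 (0.02 log units; within the scatter). Replacing the group on the carbonyl carbon has so far moved the number either within the scatter or away from a limit, so for compound 4 no step beyond the scatter is expected in this assay, a 1.1-fold lower number from compound 2 to compound 4 (0.03 log units; within the scatter). Compound 4 is therefore estimated at 100000 nM, with a range from 40000 nM to 300000 nM.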

Compound 4, half-maximal effective concentration: 136000 nM
For compound 4 the middle estimate is 1.4-fold (0.13 log units) below the measured one; measured number inside the range.
By their numbers in this assay, from the lowest: compounds 3, 2 and 4 (each within the scatter of the next). At a limit, above all of these: compound 1.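

With a 1.3-fold higher number from compound 2 to compound 4 (0.11 log units; within the scatter) and a 1.3-fold higher number from compound 3 to compound 4 (0.13 log units; within the scatter) both within the scatter, 2-(4-methylphenyl)ethenyl on the carbonyl carbon cannot be told apart from 3-chlorophenyl or (ethoxycarbonyl)methyl in this assay, so three different groups now share one band. Only 4-nitrophenyl stands apart, with an at least 2.2-fold lower number from compound 1 to compound 4 (0.34 log units; beyond the scatter) as a third step away from it. Compound 1 is the one compound held at a limit: the limit of > 300000 nM in this assay, at which 1 of the 4 values shown sits.

Open, from the compounds shown here alone, is whether an amine or a carboxylic acid on this carbonyl carbon would leave the band. Also open, going by these compounds, is what changes elsewhere on the shared core would do.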